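The source may hold more compounds than are shown below. What is called first, only, known or untested is meant among the compounds shown, and "the series" means these compounds.

Working notes on the series. Among the measured compounds shown here, in a functional assay on MCF7 cells (Homo sapiens) for antiproliferative activity, read by MTT assay, with a stated time of 48 h (on this read-out higher numbers stand for weaker inhibition and lower numbers for stronger inhibition), compound 2 `CCc1ccccc1-n1nncc1CN1C(=O)C2(C(C#N)=C(N)Oc3c(N)cc4nc5ccccc5nc4c32)c2ccccc21` gives 24600 nM, the only numerical reading in hand. Compound 1 `Cc1ccc(Cl)cc1-n1nncc1CN1C(=O)C2(C(C#N)=C(N)Oc3c2c2nc4ccccc4nc2c2ccccc32)c2ccccc21` returns only a limit in this assay, > 50000 nM. That is the situation described by the limit of > 50000 nM in this assay, at which 1 of the 2 values shown sits. Compound 1 and compound 2 differ in more than one place, so their values are set side by side only as they stand: compound 2 is read as a number, compound 1 is not.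

Compound 3 `Cc1ccc(Cl)cc1-n1nncc1CN1C(=O)C2(C(C#N)=C(N)Oc3c(N)cc4nc5ccccc5nc4c32)c2ccccc21` is not yet measured in this assay. It differs from compound 2 by 5-chloro-2-methylphenyl in place of 2-ethylphenyl on an aromatic nitrogen. The same 5-chloro-2-methylphenyl is carried by compound 1, and the only bearing on its effect is the limit of > 50000 nM in this assay, at which 1 of the 2 values shown sits, which compound 1 reaches. On that basis the step from compound 2 to compound 3 is expected to be modest, a 1.6-fold higher number from compound 2 to compound 3 (0.21 log units; within the scatter), toward weaker inhibition, with a fair chance that this assay again reports only a limit. Compound 3 is estimated at 40000 nM in this assay, with a range of 15000 nM to 100000 nM.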

Compound 3, half-maximal inhibitory concentration: 43500 nM
Beside the measured number, compound 3's estimate is 1.1-fold (0.04 log units) below it, and the stated range covers the measured number.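

Among the compounds shown here, compound 3 gives the first pair that differs in one place, and in this assay the step is a 1.8-fold higher number from compound 2 to compound 3 (0.25 log units; within the scatter), so this read-out does not tell 5-chloro-2-methylphenyl and 2-ethylphenyl apart on the aromatic nitrogen of the five-membered ring. The change swaps one carbon for one chlorine at an equal heavy-atom count and leaves the single six-membered aromatic ring in place, so this position has now been probed only with closely matched aryl groups, and neither of them brings the reading out of the weak range. The 5-chloro-2-methylphenyl group now has a numerical reading on the core of compound 3, whereas compound 1, with the same group on its own core, gives a limit and not a number: the limit of > 50000 nM in this assay, at which 1 of the 3 values shown sits.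

On these data alone, what remains open is whether anything at this position moves the reading beyond the scatter, for example a phenyl ring bearing a carboxylic acid or a dimethylamino group, or a longer chain such as n-butyl in place of the aryl ring. The two compounds in the pair also say nothing about the separate contribution of the chlorine or of the shorter methyl chain, since both change together.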